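Aryloxy-cyclohexyl ureas: ortho-trifluoromethylphenyl ether in place of chlorophenyl

The source may hold more compounds than are shown below. What is called first, only, known or untested is meant among the compounds shown, and "the series" means these compounds.

Compound 1 `O=C(Nc1ccc(Br)cc1)N[C@H]1CC[C@H](Oc2ccc(F)cc2)CC1` in a functional assay on CRL2813 cells (Homo sapiens) for cytotoxicity, read by sulforhodamine B assay, with a stated time of 5 days (on this read-out lower numbers stand for stronger inhibition and higher numbers for weaker inhibition), gives > 20000 nM, a limit of the assay rather than a number, matching (the limit of > 20000 nM in this assay, at which 1 of the 3 values shown sits). Among the measured compounds shown here, compound 2 `COC(=O)c1ccc(NC(=O)N[C@H]2CC[C@H](Oc3ccc(F)cc3)CC2)cc1` gives 11600 nM in this assay, and the step of an at least 1.7-fold lower number from compound 1 to compound 2 (0.23 log units; that floor lies within the scatter) is the only single-point change measured so far. Compound 3 `O=C(Nc1cccc(C(F)(F)F)c1)N[C@H]1CC[C@H](Oc2ccc(Cl)cc2)CC1` gives 2000 nM in this assay, the lowest number among the measured compounds, with compound 2 as its nearest neighbour at a gap beyond the scatter.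

Compound 4 `O=C(Nc1cccc(C(F)(F)F)c1)N[C@H]1CC[C@H](Oc2ccccc2C(F)(F)F)CC1` differs from compound 3 by 2-(trifluoromethyl)phenyl in place of 4-chlorophenyl on an oxygen on a saturated carbon. For the measured compounds named here, the one measured step concerns the aryl urea side, not the ether side, so no measured step bears on this change and its size is unknown from the data. With no guidance, compound 4 is expected to give 3000 nM in this assay, estimated between 800 nM and 12000 nM. The expected step of a 1.5-fold higher number from compound 3 to compound 4 (0.18 log units; within the scatter) is thus none beyond the scatter, with wide uncertainty.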

Compound 4, half-maximal inhibitory concentration: 1400 nM
Compound 4: the middle estimate sits 2.1-fold (0.33 log units) above what was measured; the range from low to high includes it.
By their numbers in this assay, from the lowest: compounds 4 and 3 (each within the scatter of the next); then compound 2. At a limit, above all of these: compound 1.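

In this assay the aryl group on the ether oxygen can change from 4-chlorophenyl to 2-(trifluoromethyl)phenyl with no shift beyond the scatter (a 1.4-fold lower number from compound 3 to compound 4 (0.15 log units; within the scatter)). Among the compounds shown here, this is the first measured step on the ether side of the series, as the earlier step concerned only the aryl urea side, and it shows that this position accepts a change of both the substituent and its place on the ring. The measurements at hand give no account of why the number holds.

Because substituent and ring place change together, the contribution of each alone stays unresolved. Also open, from the compounds shown here alone, is whether an amine or a carboxylic acid on the ether aryl ring, or a longer chain in place of that ring, would move the number beyond the scatter.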